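Three Analogues Measured, a Halogen Swap Still Untested

The source may hold more compounds than are shown below. What is called first, only, known or untested is meant among the compounds shown, and "the series" means these compounds.

Compound 1, `COc1ccc(/C=C/c2cc(OC)cc(OC)c2/C=C/C(=O)c2cc3cc(Br)cc(OC)c3oc2=O)cc1`, gives > 60000 nM in an assay on isolated protein for inhibition of Amine oxidase [flavin-containing] B (Homo sapiens), read by fluorescence, with a stated time of 15 min (a higher number here means a weaker inhibitor, a lower number a stronger inhibitor), which is a limit of this assay rather than a number.
Compound 2, `COc1ccc(/C=C/c2cc(OC)cc(OC)c2/C=C/C(=O)c2cc3ccc(Br)cc3oc2=O)cc1`, gives 55300 nM.
Compound 3, `COc1ccc(/C=C/c2cc(OC)cc(OC)c2/C=C/C(=O)c2cc3ccc(OC)cc3oc2=O)cc1`, gives 4200 nM.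

Among the two numbers actually reported, compound 2 carries the highest one, that is, it is the weaker inhibitor of the pair; compound 3 sits a 13-fold lower number from compound 2 to compound 3 (1.12 log units; beyond the scatter) away, a change produced by putting methoxy in place of bromo on an aromatic carbon. Compound 1 only reaches the limit (the limit of > 60000 nM in this assay, at which 1 of the 3 values shown sits).

Compound 4, `COc1ccc(/C=C/c2cc(OC)cc(OC)c2/C=C/C(=O)c2cc3cc(Cl)ccc3oc2=O)cc1`, differs from compound 2 by a group of 12 heavy atoms (9 carbon, 2 oxygen, 1 chlorine; one six-membered aromatic ring of carbon only, one six-membered aromatic ring with 1 hetero atom) in place of a group of 12 heavy atoms (9 carbon, 2 oxygen, 1 bromine; one six-membered aromatic ring of carbon only, one six-membered aromatic ring with 1 hetero atom), on a carbonyl carbon. Within the data shown here, no measured step exchanges one halogen for another, and no measured step moves a group on that ring; the only measured step, from bromo to methoxy, was large. With chlorine replacing bromine and no methoxy entering, the change to this assay is expected to be modest, a 1.8-fold lower number from compound 2 to compound 4 (0.27 log units; within the scatter), so compound 4 is estimated at 30000 nM, within a range of 8000 nM to 100000 nM.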

Compound 4, half-maximal inhibitory concentration: > 60000 nM
Compound 4 was reported as a limit (the forecaster's own chance of this, stated with the estimate: 35%); middle value at least 2.0-fold (0.30 log units) from the limit.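

In this assay compound 4 gives > 60000 nM, which is a limit of the assay and not a number. The step, an at least 1.0-fold higher number from compound 2 to compound 4 (0.03 log units; that floor lies within the scatter), is therefore only a floor, yet it shows that the chlorine-bearing group on this carbonyl carbon does not bring the kind of drop seen with methoxy, a 13-fold lower number from compound 2 to compound 3 (1.12 log units; beyond the scatter). Compound 1 and compound 4 both rest at the same limit: the limit of > 60000 nM in this assay, at which 2 of the 4 values shown sit.

On these data alone, how compound 4 truly compares with compound 2 stays open, and the chlorine and the bromine also stand at different places on their rings, so this step cannot separate the halogen from its place. Also open, as far as these compounds go, is whether the lower number of compound 3 belongs to methoxy alone or would also appear with an ethoxy group or an amine on the same ring carbon.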